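A few compounds are considered here, and "the series" means these few. Any claim that something is new, unique, unknown or untested is made for them only; others in the source may bear on it.

In a functional assay (aorta) with Oryctolagus cuniculus as the target (a lower number here means tighter binding, a higher number weaker binding), compound 1 (`CCCc1nc2cccnc2n1Cc1cc(Cl)c(O)c(Cl)c1`) gives 31.6 nM and compound 2 (`Oc1c(Cl)cc(Cn2c(C3CC3)nc3cccnc32)cc1Cl`) gives 20 nM, while compound 3 (`CCc1nc2c(C)ccnc2n1Cc1ccc(-c2ccccc2C(=O)O)cc1`) gives 1.26 nM as the lowest of the three numbers. Compound 4 (`C/C=C/c1nc2c(C)ccnc2n1Cc1ccc(-c2ccccc2C(=O)O)cc1`) carries prop-1-en-1-yl in place of ethyl on an aromatic carbon between two ring nitrogen atoms (prop-1-en-1-yl in place of ethyl on an aromatic carbon). Going by the values given here, the one measured step at this place swaps propyl for cyclopropyl on a different core, and that step of a 1.6-fold lower number from compound 1 to compound 2 (0.20 log units; within the scatter) stays within the scatter. The change in compound 4 is therefore expected to give no step beyond the scatter in this assay either. The expected value for compound 4 is 1.6 nM with an estimated range from 0.5 nM to 5 nM in this assay. That estimate means a 1.3-fold higher number from compound 3 to compound 4 (0.10 log units; within the scatter) as the expected step.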

Compound 4, dissociation constant: 5.01 nM
Estimate against measurement, compound 4: 3.1-fold (0.50 log units) below; measured number above the stated range.
By their numbers in this assay, from the lowest: compound 3; then compound 4; then compounds 2 and 1 (each within the scatter of the next).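

In this assay the position on the aromatic carbon between two ring nitrogen atoms responds to the change of side chain, with a 4.0-fold higher number from compound 3 to compound 4 (0.60 log units; beyond the scatter) on this core, whereas a 1.6-fold lower number from compound 1 to compound 2 (0.20 log units; within the scatter) on the other core. Prop-1-en-1-yl in place of ethyl is therefore not a silent exchange here. Nothing measured accounts for this step.

The compounds shown leave open whether the double bond or the chain length carries the step, which propyl on the core of compound 3 would separate. Also open, on these data alone, is how an amine or a butyl chain would fare at this position.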